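Estimating Lipophilicity for a Substituted Pyridinyl Ether

This account rests on a few compounds, and the source may have more. Where it says the series, first, only, none or still open, it means among the compounds named here.

Measured compounds:
- compound 1, `Cc1ccc(Oc2ccc3nc(COc4cccc(C(=O)O)c4)n(C)c3n2)cc1C`: 2.2
- compound 2, `Cn1c(COc2cccc(C(=O)O)c2)nc2ccc(Oc3ccc4c(c3)CCC4)nc21`: 2.5
- compound 3, `Cn1c(COc2cccc(C(=O)O)c2)nc2ccc(Oc3ccccn3)cc21`: 0.4

Of the compounds shown here, three sharing one core have been measured in a physicochemical assay for lipophilicity, read by LC-MS, in phosphate buffer, measured as octanol-water partition, with a stated time of 30 min, at pH 7.4, tested at 200 mM; on this read-out lower numbers stand for lower lipophilicity and higher numbers for higher lipophilicity. Compound 3 stands lowest of the three numbers: compound 1 lies nearer to it and compound 2 furthest, and both of those gaps are beyond the scatter. Within the data shown here, the one single-point step among the measured compounds, a number 0.30 log units higher from compound 1 to compound 2 (within the scatter), is within the scatter and concerns a different place on the shared core than the change now under consideration.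

Compound 4, `Cc1cc(F)cnc1Oc1ccc2nc(COc3cccc(C(=O)O)c3)n(C)c2c1`, has not been measured in this assay. It differs from compound 3 as follows: 5-fluoro-3-methylpyridin-2-yl in place of pyridin-2-yl on an oxygen on an aromatic ring. Among the measured compounds shown here, no measured step bears directly on this change, since the only recorded step swaps one carbocyclic group for another on the same oxygen, whereas here the pyridin-2-yl group gains a fluorine and a methyl. Starting from compound 3 at 0.4, a modest upward step is expected rather than none, but with considerable uncertainty given the absence of a matching precedent. The expected step is therefore a number 0.80 log units higher from compound 3 to compound 4 (beyond the scatter). Compound 4 is estimated at 1.2, with a likely range from 0.7 to 1.7.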

Compound 4, distribution coefficient: 1.1
Compound 4: the middle estimate sits 0.10 log units above what was measured; the range from low to high includes it.
By their numbers in this assay, from the lowest: compound 3; then compound 4; then compounds 1 and 2 (each within the scatter of the next).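

In this assay, among these compounds, the change from pyridin-2-yl to 5-fluoro-3-methylpyridin-2-yl on an oxygen on an aromatic ring gives a number 0.70 log units higher from compound 3 to compound 4 (beyond the scatter) and is the first step in this set to clear the scatter. Among the compounds shown here, the only earlier step, a number 0.30 log units higher from compound 1 to compound 2 (within the scatter), exchanged 3,4-dimethylphenyl for 2,3-dihydro-1H-inden-5-yl and did not show that a change on this oxygen could move the number by more than the scatter. Here the entering and leaving groups have the same kind of ring and the same counts of hydrogen-bond donors and acceptors, so the number moved with no change in any of those counts; no measurement given here accounts for the size of this step.

The fluorine and the methyl enter together. The compounds shown cannot divide the step between them, and they do not show whether either group alone would produce a step beyond the scatter. They also leave open how an amine or a longer alkyl chain in the same place on the pyridin-2-yl group would compare, and whether the same change would give a similar step on the core of compound 1.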